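Benzoyl for ethoxycarbonyl: working notes on the series

The source may hold more compounds than are shown below. What is called first, only, known or untested is meant among the compounds shown, and "the series" means these compounds.

Measured so far in a functional assay on SEM cells (Homo sapiens) for cytotoxicity, with a stated time of 72 h; on this read-out higher numbers stand for an effect only at larger amounts of compound and lower numbers for an effect already at smaller amounts:
- Compound 1 `C=C[C@@](C)(/C=C/c1ccc(O)cc1)CCC(O)C(C)(C)O` gives > 36600 nM as a limit.
- Compound 2 `C=C[C@@](C)(/C=C/c1ccc(O)cc1)CC/C=C/C(=O)OCC` gives > 36600 nM as a limit.

Compound 2 has no numerical value in this assay and gives only the limit > 36600 nM as its result. The whole evidence so far is the limit of > 36600 nM in this assay, at which 2 of the 2 values shown sit, and it offers no numerical anchor.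

The next structure is compound 3 `C=C[C@@](C)(/C=C/c1ccc(O)cc1)CC/C=C/C(=O)c1ccccc1` and the change is phenyl in place of ethoxy on a carbonyl carbon with phenyl in place of ethoxy on a carbonyl carbon, which also reads as ethoxycarbonyl to benzoyl.

Within the data shown here, the only measured step that bears on this is a step that the two limits leave unreadable from compound 1 to compound 2 and it supplies neither a size nor a direction to carry over. Any expectation is therefore loose. A readable result could only come in at lower numbers than the limit of the series, and a further limit remains quite possible.

The expected change is an at least 1.6-fold lower number from compound 2 to compound 3 (0.22 log units; that floor lies within the scatter) and this is an estimate with wide uncertainty.

For compound 3 the estimated value is 22000 nM with an expected range from 5000 nM to 40000 nM.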

Compound 3, half-maximal effective concentration: > 36600 nM
Compound 3: only a limit was reported; the forecaster's own chance of this, stated with the estimate: 55%; at least 1.6-fold (0.22 log units) between middle value and limit.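

In this assay compound 2 and compound 3 each give only a limit, and no step can be read between them, neither its size nor its direction. The series still rests on a single limit: the limit of > 36600 nM in this assay, at which 3 of the 3 values shown sit. The compounds shown leave open whether any change on the shared core gives a numerical value in this assay.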